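Swapping the furan for bromine on the shared core

The source may report more compounds than this note shows. Statements on the series, on what has been measured and on what is new or still open speak of the compounds shown alone.

Compound 2, `SC1=NC(n2nc(-c3ccccc3)nc2-c2ccccc2)=CC(c2ccc(-c3ccco3)cc2)N1`, carries a furan-2-yl group where compound 1, `SC1=NC(n2nc(-c3ccccc3)nc2-c2ccccc2)=CC(c2ccc(-c3ccccc3)cc2)N1`, has a phenyl. Within the data shown here, in a functional assay on the whole organism with Mus musculus as the target, in the maximal electroshock model, with a stated time of 4 h (on this read-out higher numbers stand for an effect only at larger amounts of compound and lower numbers for an effect already at smaller amounts), compound 2 gives 300 mg/kg, and compound 1 gives 300 mg/kg; the step of no change at the digits printed from compound 1 to compound 2 (within the scatter) left the read-out unchanged, so compound 2 stands level with compound 1 on the numbers so far.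

Compound 3, `SC1=NC(n2nc(-c3ccccc3)nc2-c2ccccc2)=CC(c2ccc(Br)cc2)N1`, is built from compound 2 by a change (bromo in place of furan-2-yl on an aromatic carbon). Among the measured compounds shown here, no measured step tests bromine at this spot; the only step known at this place, no change at the digits printed from compound 1 to compound 2 (within the scatter), shows that exchanging one ring for another there did not move the dose. On that basis no step beyond the scatter is expected for compound 3, no change at the digits printed from compound 2 to compound 3 (within the scatter). Compound 3 is therefore estimated to require 300 mg/kg in this assay, with a range from 100 mg/kg to 600 mg/kg.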

Compound 3, minimum effective dose: 300 mg/kg
Compound 3: the middle estimate sits on the measured number at the digits printed, and the stated range covers the measured number.
By their numbers in this assay, from the lowest: compounds 1, 2 and 3 (each within the scatter of the next).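

In this assay, a lone bromo group takes the place of the furan-2-yl ring with no change at the digits printed from compound 2 to compound 3 (within the scatter), and it takes the place of the phenyl ring with no change at the digits printed from compound 1 to compound 3 (within the scatter). Earlier, only one ring had been exchanged for another; these steps show that, among these three compounds, the minimum effective dose stays level even when the group on this aromatic carbon, para to a large group, has no ring at all. Nothing at hand explains why the dose stays level across these groups.

As far as these compounds go, whether a group of another kind at this spot, such as an amine or a carboxylic acid, would shift the dose remains open. So does the effect of changes elsewhere on the shared core, as these three compounds differ at this one place only.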